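Replacing the aryl amide by a tert-butyl amide

The source may report more compounds than this note shows. Statements on the series, on what has been measured and on what is new or still open speak of the compounds shown alone.

Measured compounds:
compound 1, `COc1ccccc1C(=O)Nc1ccc2[nH]cc(C3CCN(C)CC3)c2n1`: 20 nM
compound 2, `Cc1ccc(C(=O)Nc2ccc3[nH]cc(C4CCN(C)CC4)c3n2)cc1`: 12 nM

Within the data shown here, in an assay for binding affinity to 5-hydroxytryptamine receptor 1F (Homo sapiens), read by radioligand binding (on this read-out lower numbers stand for stronger inhibition and higher numbers for weaker inhibition), compound 2 gives the lowest of the two numbers, yet the only measured step, a 1.7-fold lower number from compound 1 to compound 2 (0.22 log units; within the scatter), lies within the scatter, so compound 1 and compound 2 cannot be told apart on this read-out.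

Compound 3, `CN1CCC(c2c[nH]c3ccc(NC(=O)C(C)(C)C)nc23)CC1`, differs from compound 2 by tert-butyl in place of 4-methylphenyl on a carbonyl carbon. Among the measured compounds shown here, the single measured step exchanges one six-membered aromatic ring of carbon only for another and says nothing about removing the ring in favour of a chain; no measured pair addresses that change. The direction of the step in this assay is therefore open, and the uncertainty is wide.

Compound 3 is estimated at 40 nM, with a range from 8 nM to 250 nM. The implied step a 3.3-fold higher number from compound 2 to compound 3 (0.52 log units; beyond the scatter) is expected to be modest, and a stronger or weaker outcome would not be surprising.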

Compound 3, inhibition constant: 62 nM
Compound 3: the middle estimate sits 1.6-fold (0.19 log units) below what was measured, within the range that was stated.
By their numbers in this assay, from the lowest: compounds 2 and 1 (each within the scatter of the next); then compound 3.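

Unlike the exchange of one aromatic ring for another, replacing the ring on this carbonyl carbon with a chain-type group produces a change that can be read in this assay: tert-butyl gives a 5.2-fold higher number from compound 2 to compound 3 (0.71 log units; beyond the scatter), and a 3.1-fold higher number from compound 1 to compound 3 (0.49 log units; beyond the scatter). Both steps lie beyond the scatter, so the two aryl amides, which cannot be told apart, share a lower number than the tert-butyl amide. The change is modest, however, so a six-membered aromatic ring of carbon only is not required at this place for a measurable number. The data shown offer no explanation for this difference.

The compounds shown leave open how a cyclohexyl group, which keeps a ring without aromaticity, or a straight butyl chain would read on this carbonyl carbon. They also leave open the effect of a pyridine ring there.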